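Chloro on the benzyl ring of a sulfonamide series

This account rests on a few compounds, and the source may have more. Where it says the series, first, only, none or still open, it means among the compounds named here.

Three sulfonamides sharing one core have been measured in a functional assay on ASPC1 cells (Homo sapiens) for inhibition, read by MTT assay, with a stated time of 72 h; a lower number here means a stronger inhibitor of growth, a higher number a weaker inhibitor of growth. Compound 1 `O=S(=O)(NCCCCNCc1ccc(Br)cc1)c1cc(C(F)(F)F)cc(C(F)(F)F)c1` gives 2900 nM, compound 2 `O=S(=O)(NCCCNCc1ccc(Cl)c(C(F)(F)F)c1)c1cc(C(F)(F)F)cc(C(F)(F)F)c1` gives 9600 nM, and compound 3 `O=S(=O)(NCCCNCc1ccccc1)c1cc(C(F)(F)F)cc(C(F)(F)F)c1` gives 13000 nM. Compound 3 thus holds the highest of the three numbers: the step of a 1.4-fold higher number from compound 2 to compound 3 (0.13 log units; within the scatter) is within the scatter, while the step of a 4.5-fold higher number from compound 1 to compound 3 (0.65 log units; beyond the scatter) is beyond it, so compound 3 is separated clearly only from compound 1.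

Compound 4 `O=S(=O)(NCCCNCc1cccc(Cl)c1)c1cc(C(F)(F)F)cc(C(F)(F)F)c1` has not yet been tested. It differs from compound 3 by chloro in place of hydrogen on an aromatic carbon; read one bond further out, this is benzylamino going to (3-chlorobenzyl)amino. Going by the values given here, two measured steps bear on this, both running in the opposite direction, from a halogen-bearing benzyl group to the bare benzyl: the larger one, a 4.5-fold higher number from compound 1 to compound 3 (0.65 log units; beyond the scatter), also carries a change in chain length, and the smaller one, a 1.4-fold higher number from compound 2 to compound 3 (0.13 log units; within the scatter), carries a trifluoromethyl along with the chloro. Among the compounds with values here, neither step is the single change at hand, so the expectation rests on both loosely. A lower number than compound 3 is expected for compound 4, by a step of a 1.6-fold lower number from compound 3 to compound 4 (0.21 log units; within the scatter), and the estimate is 8000 nM with a range from 3500 nM to 20000 nM.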

Compound 4, concentration for 50% growth inhibition: 5900 nM
Compound 4: the middle estimate sits 1.4-fold (0.13 log units) above what was measured; measured number inside the range.
By their numbers in this assay, from the lowest: compound 1; then compounds 4, 2 and 3 (each within the scatter of the next, the first and the last beyond it).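

In this assay, chloro in place of hydrogen on an aromatic carbon, meta to a large group, now stands as a single change on the benzyl ring, with no change of chain and no second group alongside it: a 2.2-fold lower number from compound 3 to compound 4 (0.34 log units; beyond the scatter). The step shows that this one chlorine is enough to move the number beyond the scatter, while a 1.6-fold lower number from compound 2 to compound 4 (0.21 log units; within the scatter) leaves the 3-chlorophenyl and 4-chloro-3-(trifluoromethyl)phenyl groups unseparated, and a 2.0-fold higher number from compound 1 to compound 4 (0.31 log units; beyond the scatter) shows that the (3-chlorobenzyl)amino group does not close the gap to the ((4-bromobenzyl)amino)methyl group, a step that changes both the halogen and the chain and so cannot be assigned to either. Nothing given here explains why the chloro has this effect.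

On these data alone, it remains open whether fluoro, bromo, methyl or methoxy at this same place would give a similar step, and whether chloro alone on the ring would behave differently at the position held by bromo in compound 1. As far as these compounds go, it is also open whether a longer chain would add to the step when combined with the 3-chlorobenzyl group.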